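The source may hold more compounds than are shown below. What is called first, only, known or untested is meant among the compounds shown, and "the series" means these compounds.

Measured in a functional assay on RAW264.7 cells (Mus musculus) for inhibition, read by Griess assay, with stated times of 3 h and 24 h; a lower number here means a stronger inhibitor, a higher number a weaker inhibitor:
- compound 1 `C=C1CC[C@H]2[C@@](C)(CCC(=O)N[C@@]2(C)CO)[C@@H]1/C=C/C1=CCOC1=O`: > 50000 nM (a limit)
- compound 2 `C=C1CC[C@H]2[C@@](C)(CCC(=O)N[C@@]2(C)COC(=O)c2ccc([N+](=O)[O-])cc2)[C@@H]1/C=C/C1=CCOC1=O`: 33500 nM

Among the compounds with values here, compound 2 holds the only actual number in this assay so far. Compound 1 gives only a limit: the limit of > 50000 nM in this assay, at which 1 of the 2 values shown sits.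

Compound 3 `C=C1CC[C@H]2[C@@](C)(CCC(=O)N[C@@]2(C)COC(=O)[C@H](N)CC(C)C)[C@@H]1/C=C/C1=CCOC1=O` changes the ester group of compound 2: 1-amino-3-methylbutyl in place of 4-nitrophenyl on a carbonyl carbon. Within the data shown here, the only measured step that bears on this is an at least 1.4-fold lower number from compound 1 to compound 2 (0.17 log units; that floor lies within the scatter), which introduced the group now being replaced. Among the measured compounds shown here, with only that step as a guide, the expectation is no change beyond the scatter in this assay, and a result at the limit remains possible. The estimated step is a 1.1-fold lower number from compound 2 to compound 3 (0.05 log units; within the scatter). For compound 3 the estimate is 30000 nM, with an expected range of 12000 nM to 60000 nM.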

Compound 3, half-maximal inhibitory concentration: > 50000 nM
Compound 3: a limit, no number; the forecaster's own chance of this, stated with the estimate: 35%; middle value at least 1.6-fold (0.22 log units) away from the limit.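

In this assay, compound 3 gives only a limit, > 50000 nM. Replacing 4-nitrophenyl with 1-amino-3-methylbutyl on the carbonyl carbon gives an at least 1.4-fold higher number from compound 2 to compound 3 (0.17 log units; that floor lies within the scatter), so the ester with an amino-bearing chain yields no number and no loss beyond the scatter is established. The step between compound 1 and compound 3 cannot be read, and limits now make up most of the series: the limit of > 50000 nM in this assay, at which 2 of the 3 values shown sit.

Going by these compounds, whether a plain phenyl or a 4-aminophenyl on the same carbonyl carbon gives a number in this assay remains open. So does whether the 4-nitrophenyl ester differs from the free alcohol at all.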